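Fused-heterocycle ethers: a bicyclic amine replaces acetamidopiperidine

The source may report more compounds than this note shows. Statements on the series, on what has been measured and on what is new or still open speak of the compounds shown alone.

Measured compounds
- compound 1 `c1ccc2sc(Oc3ccc4c(CN5CCCCC5)coc4c3)nc2c1`: 67 nM
- compound 2 `CC(=O)NC1CCN(Cc2coc3cc(Oc4nc5ccccc5s4)ccc23)CC1`: 26 nM

Compound 2 stands lowest of the two numbers in an in vitro assay on Sf9 cells for inhibition of leukotriene A-4 hydrolase (Homo sapiens), read by immunoassay, with stated times of 10 min and 30 min; a lower number here means a stronger inhibitor, a higher number a weaker inhibitor; the nearest is compound 1, which gives 67 nM. For the measured compounds named here, the one step seen, a 2.6-fold lower number from compound 1 to compound 2 (0.41 log units; beyond the scatter), came from acetamido in place of hydrogen on a saturated ring carbon.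

Compound 3 `CC(=O)N1C[C@@H]2C[C@H]1CN2Cc1coc2cc(Oc3nc4ccccc4s3)ccc12` differs from compound 2 by a group of 10 heavy atoms (7 carbon, 2 nitrogen, 1 oxygen; 2 five-membered non-aromatic rings with 1 hetero atom each) in place of a group of 10 heavy atoms (7 carbon, 2 nitrogen, 1 oxygen; one six-membered non-aromatic ring with 1 hetero atom), on a saturated chain carbon bound to an aromatic carbon. Going by the values given here, the acetyl amide is retained, but the single hydrogen-bond donor of compound 2 is gone and the six-membered ring becomes two five-membered rings with defined stereocentres. Among the compounds with values here, the only step on record bears on this only loosely: it shows the acetamido group itself earns a modest gain, not how its frame may be rebuilt. A change in this assay is therefore expected to be small, if anything a slight weakening, roughly a 1.5-fold higher number from compound 2 to compound 3 (0.19 log units; within the scatter). Compound 3 is estimated at 40 nM, with a range from 15 nM to 110 nM.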

Compound 3, half-maximal inhibitory concentration: 34 nM
Beside the measured number, compound 3's estimate is 1.2-fold (0.07 log units) above it; low and high end bracket the measured number.
By their numbers in this assay, from the lowest: compounds 2, 3 and 1 (each within the scatter of the next, the first and the last beyond it).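

In this assay, the group with 2 five-membered non-aromatic rings and 2 defined stereocentres can stand in for 4-acetamidopiperidin-1-yl on a saturated chain carbon bound to an aromatic carbon, with a 1.3-fold higher number from compound 2 to compound 3 (0.12 log units; within the scatter); at this place, the number therefore tolerates a rebuilt ring frame and a group with 0 hydrogen-bond donors in place of one with 1. The comparison with the unsubstituted ring of compound 1 is less clear, with a 2.0-fold lower number from compound 1 to compound 3 (0.29 log units; within the scatter), so the rebuilt group cannot be separated from either neighbour in this assay. Nothing available explains these numbers.

Open, going by these compounds, is whether a free amine or a carboxylic acid in place of the acetyl group would hold the number at this level. Also open, on these data alone, is how the mirror-image form of the new group would read.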